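A few compounds are considered here, and "the series" means these few. Any claim that something is new, unique, unknown or untested is made for them only; others in the source may bear on it.

All three compounds share one core, and all were tested for how much they harm cultured liver cells in an ADME assay on HepG2 2.2.15 cells (Homo sapiens) for cytotoxicity, read by MTT assay, with stated times of 48 h and 9 days; on this read-out higher numbers stand for lower toxicity in this test and lower numbers for higher toxicity in this test. Compound 1 `O=C(/C=C/c1coc2cc(O)ccc2c1=O)NCc1ccc(F)cc1` gives 357000 nM. Compound 3 `O=C(/C=C/c1coc2cc(O)ccc2c1=O)NCc1ccccc1` gives 436000 nM. Compound 2 `COc1ccc2c(=O)c(/C=C/C(=O)Nc3ccc(Cl)cc3)coc2c1` gives 272000 nM. The three numbers lie within the scatter of one another, so compound 2 cannot be told apart from compound 1 or compound 3 on this read-out.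

Compound 4 `COc1ccc2c(=O)c(/C=C/C(=O)NCc3ccc(C)cc3)coc2c1` differs from compound 2 in one place: 4-methylbenzyl in place of 4-chlorophenyl on an amide-type nitrogen. Going by the values given here, the only measured step in the set, a 1.2-fold higher number from compound 1 to compound 3 (0.09 log units; within the scatter), swaps a single atom on the ring at the far end of the amide, and it produced nothing beyond the scatter. Among the compounds with values here, that step is a weak guide here, since the present change also inserts a one-carbon link between the amide nitrogen and the ring, and no measured pair shows that link on its own. With nothing in the data pointing either way, the expected step in this assay from compound 2 to compound 4 is a 1.2-fold higher number from compound 2 to compound 4 (0.07 log units; within the scatter), none beyond the scatter. Compound 4 is therefore estimated at 320000 nM, with a range of 150000 nM to 650000 nM.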

Compound 4, half-maximal cytotoxic concentration: 257000 nM
Compound 4: middle estimate off by 1.2-fold (0.10 log units), on the high side, within the range that was stated.
By their numbers in this assay, from the lowest: compounds 4, 2, 1 and 3 (each within the scatter of the next).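

In this assay, putting 4-methylbenzyl in place of 4-chlorophenyl on the amide-type nitrogen gives a 1.1-fold lower number from compound 2 to compound 4 (0.02 log units; within the scatter). This is a whole-group exchange, broader than the single-atom swap seen earlier, and it still leaves the number within the scatter, so this position tolerates at least this one larger change on this read-out. Because chloro gives way to methyl and phenyl gives way to benzyl in the same step, the two changes cannot be separated, and they may either have little effect or offset each other; nothing measured here explains the flat result.

As far as these compounds go, it remains open whether each change alone would leave the number within the scatter. From the compounds shown here alone, it is also open whether a different kind of group on this nitrogen, such as an amine or a carboxylic acid on the far ring, would move it beyond the scatter.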